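Aryl Sulfonamide Swap on a Dichlorobenzamide Scaffold

This account rests on a few compounds, and the source may have more. Where it says the series, first, only, none or still open, it means among the compounds named here.

In a functional assay on HEK293 cells for agonist activity at probable G-protein coupled receptor 27 (Homo sapiens), read by a luciferase reporter and beta-arrestin recruitment, with a stated time of 10 min (a lower number here means that less compound is needed, a higher number that more compound is needed for the effect), the measured compounds stand as follows:
compound 1, `O=C(Nc1cccc(S(=O)(=O)Nc2ccccc2)c1)c1ccc(Cl)cc1Cl`, gives > 100000 nM, a limit of the assay;
compound 2, `O=C(Nc1ccc(S(=O)(=O)NCc2ccccc2)cc1)c1ccc(Cl)cc1Cl`, gives > 100000 nM, likewise a limit;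
compound 3, `O=C(Nc1ccc(S(=O)(=O)Nc2ccccc2)cc1)c1ccc(Br)cc1F`, gives 479 nM.

Compound 2 thus has no number of its own in this assay, only the limit, and it shares the limit of > 100000 nM in this assay, at which 2 of the 3 values shown sit, with compound 1. Compound 4, `O=C(Nc1ccc(S(=O)(=O)Nc2ccc(Cl)cc2)cc1)c1ccc(Cl)cc1Cl`, differs from compound 2 by 4-chlorophenyl in place of benzyl on a sulfonamide nitrogen. Among the measured compounds shown here, no measured step covers this change, but compound 3, the one compound carrying an aryl group on the sulfonamide nitrogen, gives 479 nM, so an improvement well beyond the scatter is expected, with the step from compound 2 to compound 4 estimated at an at least 66-fold lower number from compound 2 to compound 4 (1.82 log units; beyond the scatter). Compound 4 is therefore estimated at 1500 nM, within 200 nM to 30000 nM.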

Compound 4, half-maximal effective concentration: > 100000 nM
Compound 4 was reported as a limit; the forecaster's own chance of this, stated with the estimate: 35%; middle value at least 66-fold (1.82 log units) from the limit.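

Compound 2 and compound 4 both stand at a limit of the assay rather than at a number, so no step can be read between them: the limit of > 100000 nM in this assay, at which 3 of the 4 values shown sit. The compounds shown leave open whether 4-chlorophenyl in place of benzyl on a sulfonamide nitrogen changes the read-out at all.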